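The source may hold more compounds than are shown below. What is called first, only, known or untested is meant among the compounds shown, and "the series" means these compounds.

Measured compounds:
- compound 1, `CN1CCC[C@H]1COc1cccnc1` — 1400 nM
- compound 2, `CCCCC#Cc1cncc(OC[C@@H]2CCCN2C)c1` — 40000 nM

In an assay on a protein complex for binding affinity to Neuronal acetylcholine receptor; alpha3/beta4 (Rattus norvegicus) (a higher number here means a weaker inhibitor, a lower number a stronger inhibitor), compound 1 gives 1400 nM. Compound 2 carries hex-1-yn-1-yl in place of hydrogen on an aromatic carbon of the shared core and gives 40000 nM, the higher of the two numbers; the step of a 29-fold higher number from compound 1 to compound 2 (1.46 log units; beyond the scatter) is large and lies well beyond the scatter. On the numbers in hand compound 2 is therefore the weaker of the two binders in this assay.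

Compound 3, `CN1CCC[C@H]1COc1cncc(C#Cc2ccccc2)c1`, is not yet measured. It differs from compound 2 as follows:
phenyl in place of butyl on a triple-bonded carbon

Within the data shown here, only one measured step exists, and it concerns a different change: the hydrogen to hex-1-yn-1-yl move from compound 1 to compound 2, which raised the number sharply. Among the measured compounds shown here, no measured pair tells how phenyl compares with butyl on a triple-bonded carbon. With the alkyne already in place in compound 2, the expectation is that compound 3 stays in the same weak region, with a step of a 1.3-fold lower number from compound 2 to compound 3 (0.12 log units; within the scatter) that is expected to fall within the scatter. Compound 3 is accordingly estimated at 30000 nM, with a range of 8000 nM to 120000 nM.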

Compound 3, inhibition constant: 8100 nM
Estimate against measurement, compound 3: 3.7-fold (0.57 log units) above; measured number inside the range.
By their numbers in this assay, from the lowest: compound 1; then compound 3; then compound 2.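

In this assay the group on the triple-bonded carbon turns out to matter in its own right: phenyl in place of butyl gives a clear change (a 4.9-fold lower number from compound 2 to compound 3 (0.69 log units; beyond the scatter)), so the earlier rise (a 29-fold higher number from compound 1 to compound 2 (1.46 log units; beyond the scatter)) does not depend on the triple bond alone. The change recovers only part of that rise, as compound 3 (8100 nM) still has a higher number than compound 1 (1400 nM). No supporting data bear on why phenyl gives a lower number than butyl at this place.

The compounds shown leave open whether the lower number belongs to the aromatic ring or simply to a group other than butyl, which cyclohexyl on the same triple-bonded carbon would help separate. They also leave open how far the number moves with a much shorter chain such as methyl, or with a pyridyl ring, a methoxy-substituted phenyl or a terminal amine in the place of phenyl.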